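A few compounds are considered here, and "the series" means these few. Any claim that something is new, unique, unknown or untested is made for them only; others in the source may bear on it.

Of the compounds shown here, three sharing one core have been tested in a functional assay on MGC-803 cells (Homo sapiens) for antiproliferative activity, read by CCK-8 assay, with a stated time of 72 h, tested at 8 uM; a lower number here means a weaker effect, a higher number a stronger effect of the compound at the concentration tested. Compound 1 `CN(C(=S)SCc1ccc(C(=O)Nc2ccccc2N)cc1)c1cccnc1` gives 82.5%. Compound 2 `CCN(Cc1ccncc1)C(=S)SCc1ccc(C(=O)Nc2ccccc2N)cc1` gives 85.2%, and compound 3 `CN1CCN(C(=S)SCc2ccc(C(=O)Nc3ccccc3N)cc2)CC1` gives 84.4%. The three differ only in the amino group attached to the thiocarbonyl carbon, and the readings barely move: a number 2.7 percentage points higher from compound 1 to compound 2 (within the scatter), a number 1.9 percentage points higher from compound 1 to compound 3 (within the scatter) and a number 0.8 percentage points lower from compound 2 to compound 3 (within the scatter). Compound 3 therefore sits in the middle of a tight cluster, with neither neighbour separated from it by more than the usual scatter, so no compound among these three can be called the strongest or weakest.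

Compound 4 `CN(Cc1cccnc1)C(=S)SCc1ccc(C(=O)Nc2ccccc2N)cc1` is not yet measured. Compared with compound 3, the change is methyl((pyridin-3-yl)methyl)amino in place of 4-methylpiperazin-1-yl on a thiocarbonyl carbon. For the measured compounds named here, the steps already seen all swap one amino group for another at the same thiocarbonyl carbon, and each stayed within the scatter; they are the only guide here, and the incoming group resembles those of compound 1 and compound 2, which gave readings close to that of compound 3.

It is therefore expected that compound 4 shows no step beyond the scatter, that is a number 0.4 percentage points lower from compound 3 to compound 4 (within the scatter), and the estimate for compound 4 in this assay is 84%, expected to fall between 76% and 91%.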

Compound 4, a percentage reported as inhibition, at one concentration (the size of the read-out at that concentration, not a potency): 85.5%
Compound 4: the middle estimate sits 1.5 percentage points below what was measured; the range from low to high includes it.
By their numbers in this assay, from the lowest: compounds 1, 3, 2 and 4 (each within the scatter of the next).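

In this assay, methyl((pyridin-3-yl)methyl)amino in place of 4-methylpiperazin-1-yl on the thiocarbonyl carbon gives a number 1.1 percentage points higher from compound 3 to compound 4 (within the scatter), so exchanging a six-membered non-aromatic ring for a six-membered aromatic ring at this position produces no readable change. The two closer comparisons agree: methyl((pyridin-3-yl)methyl)amino in place of ethyl((pyridin-4-yl)methyl)amino gives a number 0.3 percentage points higher from compound 2 to compound 4 (within the scatter), and (pyridin-3-yl)methyl in place of pyridin-3-yl on the amide-type nitrogen gives a number 3 percentage points higher from compound 1 to compound 4 (within the scatter), so neither of these swaps separates the compounds in this read-out. No measurement at hand offers an explanation for this result.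

These readings come from a single concentration and show the size of the effect at that concentration, so any differences in potency among the four compounds remain unresolved. All four groups shown on the thiocarbonyl carbon contain a ring, which leaves open whether an open-chain group such as diethylamino, or a group carrying a carboxylic acid, would stay within the same narrow range.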